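Fluoro for methyl on the indazole of compound 3

This account rests on a few compounds, and the source may have more. Where it says the series, first, only, none or still open, it means among the compounds named here.

The measured compounds, all tested in a functional assay on MCF7 cells (Homo sapiens) for cytotoxicity, read by CellTiter-Glo, with a stated time of 5 days; on this read-out higher numbers stand for weaker inhibition and lower numbers for stronger inhibition:
Compound 1 `CC/C(=C(/c1ccc(/C=C/C(=O)O)cc1)c1ccc2[nH]ncc2c1)c1ccccc1` gives 7.2 nM.
Compound 2 `O=C(O)/C=C/c1ccc(/C(=C(\c2ccccc2)C2CCCC2)c2ccc3[nH]ncc3c2)cc1` gives 10 nM.
Compound 3 `CC/C(=C(/c1ccc(/C=C/C(=O)O)cc1)c1ccc2[nH]nc(C)c2c1)c1ccccc1` gives > 1000 nM, which is a limit of the assay and not a number.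

Compound 3 therefore stands at the weak end of the three values shown, at the limit of > 1000 nM in this assay, at which 1 of the 3 values shown sits; its exact position is not known. Compound 2 differs from compound 1 only on the chain, and a 1.4-fold higher number from compound 1 to compound 2 (0.14 log units; within the scatter).

Compound 4 `CC/C(=C(/c1ccc(/C=C/C(=O)O)cc1)c1ccc2[nH]nc(F)c2c1)c1ccccc1` is compound 3 with fluoro in place of methyl on an aromatic carbon. For the measured compounds named here, the one measured step that touches this position is an at least 130-fold higher number from compound 1 to compound 3 (2.14 log units; beyond the scatter); the methyl group there carries a large loss. Going by the values given here, no measured step tells how fluoro behaves at this position. Fluoro is also a single heavy atom, so compound 4 is expected to sit between the hydrogen of compound 1 and the methyl of compound 3, with an at least 3.3-fold lower number from compound 3 to compound 4 (0.52 log units; beyond the scatter) as the expected recovery. The estimate for compound 4 in this assay is 300 nM, with a range from 30 nM to 3000 nM.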

Compound 4, half-maximal inhibitory concentration: 5 nM
Estimate against measurement, compound 4: 60-fold (1.78 log units) above, and the stated range ends above it.
By their numbers in this assay, from the lowest: compounds 4, 1 and 2 (each within the scatter of the next). At a limit, above all of these: compound 3.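

In this assay, the large loss seen with methyl on this aromatic carbon of the five-membered ring does not extend to every group placed there: fluoro in place of methyl gives an at least 200-fold lower number from compound 3 to compound 4 (2.30 log units; beyond the scatter). Fluoro and hydrogen cannot be told apart at this position, with a 1.4-fold lower number from compound 1 to compound 4 (0.16 log units; within the scatter). The step from methyl to fluoro is known only as a bound, since compound 3 holds the one value that is a limit of the assay and not a number: the limit of > 1000 nM in this assay, at which 1 of the 4 values shown sits.

The compounds shown carry only hydrogen, methyl and fluoro on this carbon, so it stays open whether chloro, a hydroxyl or an amine would side with fluoro or with methyl. On these data alone, it also stays open whether fluoro here would give the same picture alongside the cyclopentyl of compound 2.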